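Tert-butyl in place of ethyl

The source may report more compounds than this note shows. Statements on the series, on what has been measured and on what is new or still open speak of the compounds shown alone.

In a physicochemical assay for lipophilicity (a lower number here means a more polar compound, a higher number a more lipophilic compound), compound 1 (`C/C=C/C=C/C(N)=O`) gives 0.6 and compound 2 (`C/C=C/C=C/C(=O)OCC`) gives 1.84 as the higher of the two numbers. Among the measured compounds shown here, the only measured step is a number 1.24 log units higher from compound 1 to compound 2 (beyond the scatter) with ethoxy in place of amino on a carbonyl carbon, a large change beyond the scatter. The change to compound 3 (`C/C=C/C=C/C(=O)OC(C)(C)C`) is tert-butyl in place of ethyl on an oxygen next to a carbonyl group. For the measured compounds named here, no measured step matches this change, so that single step bears on it only loosely. An estimated a number 0.76 log units higher from compound 2 to compound 3 (beyond the scatter) is expected, beyond the scatter but smaller than the measured step. In this assay the estimate for compound 3 is 2.6 with an expected range from 2.2 to 3 as its bounds.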

Compound 3, partition coefficient: 2.33
Compound 3: middle estimate off by 0.27 log units, on the high side; the range from low to high includes it.
By their numbers in this assay, from the lowest: compound 1; then compound 2; then compound 3.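

In this assay, tert-butyl in place of ethyl on an oxygen next to a carbonyl group gives a number 0.49 log units higher from compound 2 to compound 3 (beyond the scatter) and so moves the number beyond the scatter, although the step is modest. The earlier step, a number 1.24 log units higher from compound 1 to compound 2 (beyond the scatter), was a large one that replaced the amino group on the carbonyl carbon, whereas this one alters only the group carried by the oxygen. No measured evidence accounts for the size of the new step.

The compounds shown leave open how methyl or a longer chain on this oxygen would compare with ethyl and tert-butyl. They also leave open where a carboxylic acid would fall.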